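Swapping a nitrile for an ester in a tolerated series

The source may hold more compounds than are shown below. What is called first, only, known or untested is meant among the compounds shown, and "the series" means these compounds.

Measured so far:
compound 1, `CCOC(=O)c1cnc(N2CCN(Cc3ccccc3C#N)CC2)nc1Oc1c(C)cc(-c2ccc(C#N)cc2)cc1C`: > 125000 nM
compound 2, `CCOC(=O)c1cnc(N2CCN(Cc3cccc(F)c3)CC2)nc1Oc1c(C)cc(-c2ccc(C#N)cc2)cc1C`: > 125000 nM

Both measured compounds share one core and were tested in an ADME assay on MT4 cells (Homo sapiens) for cytotoxicity, read by MTT assay, with a stated time of 4 days; a lower number here means that less compound is tolerated, a higher number that more compound is tolerated. Compound 1 gives > 125000 nM, which is a limit of the assay rather than a measured number. Compound 2 gives > 125000 nM, likewise a limit. For the measured compounds named here, the only measured step, a step that the two limits leave unreadable from compound 1 to compound 2, is therefore of unreadable size.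

Compound 3, `CCOC(=O)c1cnc(N2CCN(Cc3ccccc3C(=O)OC)CC2)nc1Oc1c(C)cc(-c2ccc(C#N)cc2)cc1C`, has not yet been measured. It differs from compound 1 by methoxycarbonyl in place of cyano on an aromatic carbon. Going by the values given here, no measured step speaks directly to this change, and the one step that exists cannot be read. What the data do show is this: the limit of > 125000 nM in this assay, at which 2 of the 2 values shown sit. On that basis, the cytotoxicity of compound 3 in this assay is expected to sit at the same limit, so the step that the limit leaves unreadable from compound 1 to compound 3 is expected to fall within the scatter. Compound 3 is accordingly estimated at 150000 nM, with a range from 60000 nM to 400000 nM, most likely reported again only as a limit.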

Compound 3, half-maximal cytotoxic concentration: > 125000 nM
Compound 3: a limit, no number (the forecaster's own chance of this, stated with the estimate: 80%); the middle value lies beyond the limit too.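

In this assay compound 3 gives > 125000 nM, which is a limit of the assay and not a number. Compound 1 and compound 2 stand at a limit as well, so no step among the three can be read: the limit of > 125000 nM in this assay, at which 3 of the 3 values shown sit.

The compounds shown leave open where the half-maximal cytotoxic concentration of each truly lies, and whether methoxycarbonyl in place of cyano changes it at all.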